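Acyl Swap on the Aniline Nitrogen of the Chalcone

This account rests on a few compounds, and the source may have more. Where it says the series, first, only, none or still open, it means among the compounds named here.

Compound 2 `COc1cc(/C=C/C(=O)c2cccc(NC(=O)c3ccc(Cl)cc3Cl)c2)ccc1O` stands lowest of the two numbers in a functional assay on HUVEC cells (Homo sapiens) for inhibition, tested at 10 ug/mL; on this read-out higher numbers stand for a stronger effect at the one concentration tested and lower numbers for a weaker effect: compound 2 gives 70%. Its nearest neighbour is the unsubstituted parent, compound 1 `COc1cc(/C=C/C(=O)c2cccc(N)c2)ccc1O`, which in this assay gives 90%. Going by the values given here, the one measured step in the set, a number 20 percentage points lower from compound 1 to compound 2 (beyond the scatter), shows that placing an acyl group on the aromatic nitrogen costs a modest amount of inhibition.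

Compound 3 `COC(=O)C(=O)Nc1cccc(C(=O)/C=C/c2ccc(O)c(OC)c2)c1` keeps an acyl group on that nitrogen but changes what the carbonyl carries: methoxycarbonyl in place of 2,4-dichlorophenyl on a carbonyl carbon. Among the compounds with values here, no measured step covers an exchange of one acyl group for another, so the only guide is that compound 2 with its acyl group sits a step below compound 1 in this assay, and compound 3 retains that feature. The step is therefore expected to be small, with compound 3 staying near compound 2 and no change beyond the scatter being the most likely outcome, a number 5 percentage points lower from compound 2 to compound 3 (within the scatter). Compound 3 is expected to give 65% in this assay, within a range of 40% to 85%.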

Compound 3, a percentage reported as inhibition, at one concentration (the size of the read-out at that concentration, not a potency): 43%
Compound 3: the middle estimate sits 22 percentage points above what was measured; measured number inside the range.
By their numbers in this assay, from the lowest: compound 3; then compound 2; then compound 1.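

In this assay, acylating the nitrogen on the aromatic ring does not carry one fixed cost, since what the carbonyl bears also counts: methoxycarbonyl in place of 2,4-dichlorophenyl on a carbonyl carbon gives a number 27 percentage points lower from compound 2 to compound 3 (beyond the scatter). Measured against the free amine, (methoxycarbonyl)carbonyl on this nitrogen gives a number 47 percentage points lower from compound 1 to compound 3 (beyond the scatter), a large step, whereas (2,4-dichlorophenyl)carbonyl gave only the modest a number 20 percentage points lower from compound 1 to compound 2 (beyond the scatter). Nothing available on these compounds accounts for the gap between the two acyl groups.

The two acyl groups differ at once in the aromatic ring, the chlorine atoms and the hydrogen-bond acceptors, so these compounds do not show which of these differences goes with the lower number. On these data alone, a plain benzoyl group without chlorine would separate the ring from the chlorine atoms, while a carboxylic acid in place of the methoxycarbonyl would test this end of the acyl group; how either compares remains open.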